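Ethyl in place of trifluoromethyl in compound 3

A few compounds are considered here, and "the series" means these few. Any claim that something is new, unique, unknown or untested is made for them only; others in the source may bear on it.

In a functional assay on MDA-MB-231 cells (Homo sapiens) for antiproliferative activity, with a stated time of 4 days (on this read-out lower numbers stand for stronger inhibition and higher numbers for weaker inhibition), compound 1 `CCCCc1ccc2[nH]c(-c3ccc(C(F)(F)F)cc3)c(/C=N/NC(=O)c3ccc([N+](=O)[O-])cc3)c2c1` gives 2040 nM, compound 2 `CCCCc1ccc2[nH]c(-c3ccc(OC)cc3)c(/C=N/NC(=O)c3ccncc3)c2c1` gives 29 nM and compound 3 `CCCCc1ccc2[nH]c(-c3ccc(C(F)(F)F)cc3)c(/C=N/NC(=O)c3ccncc3)c2c1` gives 94 nM. Compound 3 thus holds the middle of the three numbers, nearer to compound 2 than to compound 1.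

The next structure is compound 4 `CCCCc1ccc2[nH]c(-c3ccc(CC)cc3)c(/C=N/NC(=O)c3ccncc3)c2c1`. The change is ethyl in place of trifluoromethyl on an aromatic carbon, para to a large group.

The relevant precedent is a 3.2-fold higher number from compound 2 to compound 3 (0.51 log units; beyond the scatter), a modest step with trifluoromethyl in place of methoxy at this same place. The large step of a 22-fold lower number from compound 1 to compound 3 (1.34 log units; beyond the scatter) concerns the group on the carbonyl carbon, which compound 4 shares with compound 3, so it gives little guidance here. Going by the values given here, no ethyl compound has been measured yet.

Read in reverse, the modest step suggests a small move toward compound 2. The estimate amounts to a 1.9-fold lower number from compound 3 to compound 4 (0.27 log units; within the scatter), an expected lower number that may not clear the scatter. Compound 4 is expected at 50 nM, with an estimated range of 20 nM to 130 nM.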

Compound 4, half-maximal inhibitory concentration: 80 nM
Compound 4: the middle estimate sits 1.6-fold (0.20 log units) below what was measured, within the range that was stated.
By their numbers in this assay, from the lowest: compound 2; then compounds 4 and 3 (each within the scatter of the next); then compound 1.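

In this assay the exchange of trifluoromethyl for ethyl gives a 1.2-fold lower number from compound 3 to compound 4 (0.07 log units; within the scatter) and so does not separate these two groups at this place, although the 4-(trifluoromethyl)phenyl and 4-ethylphenyl groups differ in heavy atoms and in fluorine content. Methoxy now stands apart from both: alongside a 3.2-fold higher number from compound 2 to compound 3 (0.51 log units; beyond the scatter) there is a 2.8-fold higher number from compound 2 to compound 4 (0.44 log units; beyond the scatter) for the ethyl compound, and among the three compounds that differ only at this place, none goes against that separation. Nothing available here explains why methoxy differs from the other two groups.

As far as these compounds go, whether an amine, a carboxylic acid or a longer chain at this place would stay with compound 3 and compound 4 or move toward compound 2 remains open. Also open, from the compounds shown here alone, is whether the large gain seen with pyridin-4-yl in place of 4-nitrophenyl would carry over to the ethyl or methoxy compounds.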